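The source may report more compounds than this note shows. Statements on the series, on what has been measured and on what is new or still open speak of the compounds shown alone.

Compound 1 `Cc1cc(=O)n(-c2cccc(F)c2)nc1C(=O)Nc1ccc(Oc2ncnc3c2ccn3C)cc1`: 23400 nM
Compound 2 `Cc1ccc(-n2nc(C(=O)Nc3ccc(Oc4ncnc5c4ccn5C)cc3)c(C)cc2=O)cc1`: a limit, > 60000 nM

In a functional assay on A549 cells (Homo sapiens) for cytotoxicity, read by MTT assay, with a stated time of 72 h (a lower number here means a stronger inhibitor, a higher number a weaker inhibitor), compound 1 gives 23400 nM, the only number shown. The value of compound 2 is a limit of the assay, not a number. Going by the values given here, the one measured step, an at least 2.5-fold higher number from compound 1 to compound 2 (0.40 log units; beyond the scatter), concerns the group on the aromatic nitrogen and is bounded by the limit of > 60000 nM in this assay, at which 1 of the 2 values shown sits. Compound 3 `Cc1cc(=O)n(-c2cccc(F)c2)nc1C(=O)Nc1ccc(Oc2ncnc3c2ccn3C)c(F)c1` differs from compound 1 by fluoro in place of hydrogen on an aromatic carbon. Among the compounds with values here, no measured step touches that position, so no change beyond the scatter is expected, and compound 3 is estimated at 23000 nM, between 9000 nM and 60000 nM, a step of a 1.0-fold lower number from compound 1 to compound 3 (0.01 log units; within the scatter).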

Compound 3, half-maximal inhibitory concentration: > 60000 nM
Compound 3: a limit, no number (the forecaster's own chance of this, stated with the estimate: 20%); at least 2.6-fold (0.41 log units) between middle value and limit.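

Fluoro in place of hydrogen on this aromatic carbon, ortho to a large group and meta to a large group, does change the read-out in this assay, giving an at least 2.5-fold higher number from compound 1 to compound 3 (0.40 log units; beyond the scatter). The earlier compounds shown here showed such a change only for the group on the aromatic nitrogen, so this second position of the shared core now matters as well. The value of compound 3 is a limit and not a number, so the step has only a lower bound: the limit of > 60000 nM in this assay, at which 2 of the 3 values shown sit.

From the compounds shown here alone, how far compound 3 lies beyond that limit stays open. The compounds shown also do not tell how a chloro, a methoxy or an amine on the same carbon would read.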